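The source may hold more compounds than are shown below. What is called first, only, known or untested is meant among the compounds shown, and "the series" means these compounds.

Compound 1 `COc1ccc(N2C(=O)COc3ccc(-c4cnc5ccccc5c4)cc32)cc1` and compound 2 `COc1cccc(N2C(=O)COc3ccc(-c4cnc(Cl)c(NS(=O)(=O)c5ccc(F)cc5)c4)cc32)c1` share the same core. In a functional assay on HepG2 cells (Homo sapiens) for antiproliferative activity, read by MTT assay, with a stated time of 72 h (on this read-out higher numbers stand for weaker inhibition and lower numbers for stronger inhibition), compound 1 gives > 40000 nM, which is a limit of the assay rather than a number. In this assay compound 2 gives > 40000 nM, again a limit. Both values therefore rest at the limit of > 40000 nM in this assay, at which 2 of the 2 values shown sit. Compound 3 `O=C1COc2ccc(-c3cnc(Cl)c(NS(=O)(=O)c4ccc(F)cc4)c3)cc2N1c1ccccc1` has not yet been measured in this assay; it differs from compound 2 by hydrogen in place of methoxy on an aromatic carbon. Since compound 2 in this assay gives only > 40000 nM, no step beyond the usual scatter is expected, in either direction: a step that the limit leaves unreadable from compound 2 to compound 3. Compound 3 is accordingly estimated at 60000 nM, within a range from 20000 nM to 200000 nM.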

Compound 3, half-maximal inhibitory concentration: 35700 nM
Compound 3: middle estimate off by 1.7-fold (0.23 log units), on the high side; measured number inside the range.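

Within the data shown here, compound 3 gives the first true number in this assay at this position, 35700 nM, so the 3-methoxyphenyl to phenyl change can now be read from one side. That change gives an at least 1.1-fold lower number from compound 2 to compound 3 (0.04 log units; that floor lies within the scatter), which shows only that removing the methoxy does not take the value beyond the limit. The true size of the step stays unknown, as compound 2 still rests at a limit: the limit of > 40000 nM in this assay, at which 2 of the 3 values shown sit.

From the compounds shown here alone, it remains open whether an amine or a carboxylic acid on this aromatic carbon would shift the number beyond the scatter from compound 3.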